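Moving the methyl group on a pendant phenyl ring

The compounds below may be only part of what the source reports. "The series", "measured", "known", "first", "only" and "open" are said of these compounds alone.

Compound 1 `CCCS(=O)(=O)Nc1ccc(F)c(C(=O)c2n[nH]c3ncc(-c4ccccc4Cl)cc23)c1F` gives 9.3% in an assay for binding affinity to dual specificity mitogen-activated protein kinase kinase 4 (Homo sapiens), read by KINOMEscan, tested at 100 nM; on this read-out higher numbers stand for a weaker effect at the one concentration tested and lower numbers for a stronger effect.
Compound 2 `CCCS(=O)(=O)Nc1ccc(F)c(C(=O)c2n[nH]c3ncc(-c4cccc(F)c4)cc23)c1F` gives 8.2% in this assay.
Compound 3 `CCCS(=O)(=O)Nc1ccc(F)c(C(=O)c2n[nH]c3ncc(-c4ccccc4C)cc23)c1F` gives 7% in this assay.

All three share one core and differ only in the substituted phenyl ring attached to it. Compound 3 has the lowest of the three numbers, but its gaps to the others, a number 2.3 percentage points lower from compound 1 to compound 3 (within the scatter) and a number 1.2 percentage points lower from compound 2 to compound 3 (within the scatter), both lie within the scatter, so the three cannot be told apart on these data.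

Compound 4 `CCCS(=O)(=O)Nc1ccc(F)c(C(=O)c2n[nH]c3ncc(-c4ccc(C)cc4)cc23)c1F` differs from compound 3 by 4-methylphenyl in place of 2-methylphenyl on an aromatic carbon. Among the measured compounds shown here, the two measured steps that touch this ring, a number 2.3 percentage points lower from compound 1 to compound 3 (within the scatter) and a number 1.2 percentage points lower from compound 2 to compound 3 (within the scatter), swap one group for another and were both within the scatter; no measured step moves a methyl from one position of the ring to another. With all observed changes at this ring staying within the scatter, the step of a number 1 percentage points higher from compound 3 to compound 4 (within the scatter) is expected to be small and without a clear direction. Compound 4 is therefore estimated at 8%, with a range from 3% to 16%.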

Compound 4, a percentage reported as activity, at one concentration (the size of the read-out at that concentration, not a potency): 5.4%
Beside the measured number, compound 4's estimate is 2.6 percentage points above it; the measured number falls inside the stated range.
By their numbers in this assay, from the lowest: compounds 4, 3, 2 and 1 (each within the scatter of the next).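

Moving the methyl group, which turns the 2-methylphenyl into the 4-methylphenyl with the same atoms joined differently, gives a number 1.6 percentage points lower from compound 3 to compound 4 (within the scatter) in this assay and is the first direct test of where the methyl sits on this ring. The other two new comparisons, a number 2.8 percentage points lower from compound 2 to compound 4 (within the scatter) and a number 3.9 percentage points lower from compound 1 to compound 4 (within the scatter), also stay inside the scatter, so all four compounds remain indistinguishable on this read-out and none of these substituted phenyl rings stands out. Nothing available here bears on why these differences are so small. The compounds shown leave open whether a clearly different group on this phenyl ring, such as an amine, a carboxylic acid or a longer chain, would shift the number beyond the scatter.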